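Saturated chain length and a first unsaturated chain

The source may hold more compounds than are shown below. What is called first, only, known or untested is meant among the compounds shown, and "the series" means these compounds.

In an ADME assay on cells (Fibroblast, Homo sapiens) for antiproliferative activity, read by sulforhodamine B assay, with a stated time of 48 h (on this read-out lower numbers stand for stronger inhibition and higher numbers for weaker inhibition), compound 1 `CCCCCCCCCCCCNC(=O)[C@@H]1CSC(c2ccc(NC(C)=O)cc2)N1` gives 3500 nM and compound 2 `CCCCCCCCCCCCCCCNC(=O)[C@@H]1CSC(c2ccc(NC(C)=O)cc2)N1` gives 14300 nM on a longer saturated chain. Compound 3 `CCCCCCCCCCCCCCCCCNC(=O)[C@@H]1CSC(c2ccc(NC(C)=O)cc2)N1` gives 35800 nM on the longest saturated chain, the highest of the three numbers. The numbers rise as the saturated chain grows: a 4.1-fold higher number from compound 1 to compound 2 (0.61 log units; beyond the scatter) is followed by a 2.5-fold higher number from compound 2 to compound 3 (0.40 log units; beyond the scatter) and the whole run amounts to a 10-fold higher number from compound 1 to compound 3 (1.01 log units; beyond the scatter) with none of the three compounds going against it.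

Compound 4 `CCCCCCCCC/C=C\CCCCCCCNC(=O)[C@@H]1CSC(c2ccc(NC(C)=O)cc2)N1` carries this change: a group of 11 heavy atoms (11 carbon; no ring) in place of a group of 10 heavy atoms (10 carbon; no ring), on a saturated chain carbon, seven bonds along the chain from an amide-type nitrogen and the entering group holds 1 double bond outside aromatic rings. The nearest guide is a 2.5-fold higher number from compound 2 to compound 3 (0.40 log units; beyond the scatter) on a saturated chain, and it points to a small rise at most for the one added carbon. Within the data shown here, no measured compound carries a double bond, so the data give no size for that part of the change. No step beyond the scatter is therefore expected, and the expected step is a 1.2-fold lower number from compound 3 to compound 4 (0.08 log units; within the scatter) in this assay with wide uncertainty. For compound 4 the estimated value is 30000 nM with an expected range from 9000 nM to 75000 nM as the working figures.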

Compound 4, half-maximal inhibitory concentration: 10600 nM
Compound 4: middle estimate off by 2.8-fold (0.45 log units), on the high side; measured number inside the range.
By their numbers in this assay, from the lowest: compound 1; then compounds 4 and 2 (each within the scatter of the next); then compound 3.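

In this assay, the entering chain with its double bond reverses the rise seen along the saturated chains: despite holding one more carbon than the decyl group it replaces, it gives a 3.4-fold lower number from compound 3 to compound 4 (0.53 log units; beyond the scatter), so compound 4 goes against the trend of higher numbers with longer chains. The change, on a saturated chain carbon seven bonds along the chain from an amide-type nitrogen, leaves compound 4 level with the shorter saturated chain of compound 2 (a 1.3-fold lower number from compound 2 to compound 4 (0.13 log units; within the scatter)), but it does not reach compound 1 (a 3.0-fold higher number from compound 1 to compound 4 (0.48 log units; beyond the scatter)). No measurement at hand accounts for this result.

The added carbon and the double bond enter together, so their separate contributions cannot be read from this step. A fully saturated chain of the same carbon count, a second double bond or a chain ending in a carboxylic acid would remain to be compared.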